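Lengthening a Hydroxy-Terminated Chain into a Hexadecyl Chain

This account rests on a few compounds, and the source may have more. Where it says the series, first, only, none or still open, it means among the compounds named here.

Of the compounds shown here, three built on one shared core have been tested in a functional assay on cells (Lymphocyte, Homo sapiens), read by trypan blue exclusion, with a stated time of 16 h, tested at 2.5 uM; a lower number here means a weaker effect, a higher number a stronger effect of the compound at the concentration tested. In this assay compound 1 `CCCCCCCCCCc1c(C)c(N(C)C)nc(C)c1O` gives 86%. Compound 2 `Cc1c(N(C)C)nc(CCCCCCCCCCO)c(O)c1C` gives 87% in this assay. Compound 3 `CCCCCCCCCCCCCCCCc1c(C)c(N2CCC2)nc(C)c1O` gives 92% in this assay. Compound 2 thus holds the second highest of the three numbers, with compound 1 lying closest and compound 3 farthest from it, yet both gaps sit within the usual scatter of this assay, so the three readings cannot be told apart.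

Compound 4 `CCCCCCCCCCCCCCCCc1nc(N(C)C)c(C)c(C)c1O` has not yet been measured. Compared with compound 2 it shows (hexyl in place of hydroxy on a saturated chain carbon, ten or more bonds along the chain from an aromatic carbon). For the measured compounds named here, no two measured compounds differ in only one place, so this step has no measured counterpart. The three measured compounds carry chains of differing length, with or without a hydroxy at the far end, and all give readings close together in this assay. On that basis a step of no more than the scatter is expected, in either direction. Compound 4 is therefore estimated at 90%, with a range from 80% to 97%. The expected step of a number 3 percentage points higher from compound 2 to compound 4 (within the scatter) is small and falls within the scatter.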

Compound 4, a percentage reported as activity, at one concentration (the size of the read-out at that concentration, not a potency): 92%
Compound 4: the middle estimate sits 2 percentage points below what was measured; the range from low to high includes it.
By their numbers in this assay, from the lowest: compounds 1, 2, 3 and 4 (each within the scatter of the next).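

In this assay the exchange of hydroxy for hexyl on a saturated chain carbon amounts to a number 5 percentage points higher from compound 2 to compound 4 (within the scatter) and gives the set its first comparison of compounds that differ in one place. For the compounds shown here, the earlier compounds could show only that their readings lay close together, whereas this pair shows directly that the far end of the chain can lose the hydroxy, with its hydrogen-bond donor and acceptor, and gain hexyl without a difference this assay can resolve. The pair offers no explanation for this, as no measurement bearing on the cause is available.

On these data alone, whether other groups at the end of the chain, such as an amine or a carboxylic acid, or a chain longer than hexadecyl, would also leave the reading unchanged remains open. The readings also come from a single concentration, so they cannot show whether compound 2 and compound 4 would separate at lower concentrations, where one might show a stronger or weaker effect at that concentration than the other.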